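From 4-methoxyphenyl to 2,5-dichlorophenyl on the shared core

A few compounds are considered here, and "the series" means these few. Any claim that something is new, unique, unknown or untested is made for them only; others in the source may bear on it.

In an ADME assay on MDBK cells (Bos taurus) for cytotoxicity, read by MTT assay (on this read-out lower numbers stand for higher toxicity in this test and higher numbers for lower toxicity in this test), compound 3 (`COc1ccc(OCCCCCCN2C[C@H](O)[C@@H](O)[C@H](O)[C@H]2CO)cc1`) gives > 500000 nM, which is a limit and not a number. Compound 1 (`OC[C@@H]1[C@@H](O)[C@H](O)[C@@H](O)CN1CCCCCCOc1ccc(OC(F)(F)F)cc1`) gives > 500000 nM, which is also a limit. The series therefore sits largely at the limit of > 500000 nM in this assay, at which 2 of the 3 values shown sit. Among the compounds with values here, compound 2 (`CCCC1CCCCC1OCCCCCCN1C[C@H](O)[C@@H](O)[C@H](O)[C@H]1CO`) gives 150000 nM, the only true number so far.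

Compound 4 (`OC[C@@H]1[C@@H](O)[C@H](O)[C@@H](O)CN1CCCCCCOc1cc(Cl)ccc1Cl`) differs from compound 3 by 2,5-dichlorophenyl in place of 4-methoxyphenyl on an oxygen on a saturated carbon, with 2,5-dichlorophenyl in place of 4-methoxyphenyl on an oxygen on a saturated carbon.

Within the data shown here, two measured steps bear on this change. Among the measured compounds shown here, the first is a step that the two limits leave unreadable from compound 1 to compound 3, which offers no size to carry over. For the measured compounds named here, the second is an at least 3.3-fold higher number from compound 2 to compound 3 (0.52 log units; beyond the scatter), the only readable step. It swaps a different pair of groups, but at the same kind of place, and it shows that a change there can separate a number from the limit. Going by the values given here, no measured step involves the chlorine-bearing group, so the size stays uncertain.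

A modest move to a lower number in this assay is expected, and a reading that stays at the limit remains quite possible. The expected change is an at least 1.6-fold lower number from compound 3 to compound 4 (0.22 log units; that floor lies within the scatter). Compound 4 is estimated at 300000 nM, with an expected range of 100000 nM to 700000 nM.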

Compound 4, half-maximal cytotoxic concentration: 320000 nM
Compound 4: middle estimate off by 1.1-fold (0.03 log units), on the low side, and the stated range covers the measured number.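

Compound 4 is the only compound shown with an aromatic group at this place that gives a true number in this assay, and this turns the change at the oxygen into a step with a readable lower bound. The move to 2,5-dichlorophenyl gives an at least 1.5-fold lower number from compound 3 to compound 4 (0.19 log units; that floor lies within the scatter), so only a floor is known, and that floor does not separate the two compounds beyond the usual spread of repeat measurements. Compound 2 can now be set against an aromatic group with two true numbers, giving a 2.1-fold higher number from compound 2 to compound 4 (0.33 log units; beyond the scatter), although the series still sits largely at its ceiling: the limit of > 500000 nM in this assay, at which 2 of the 4 values shown sit.

Going by these compounds, how far compound 3 lies past its limit remains open, and with it the true size of the step to compound 4. The compounds shown also do not tell whether one chlorine on the aromatic ring would give a number like that of compound 4, or how an amine or a carboxylic acid on that ring, or a chain longer than the shared one, would read in this assay.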